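This account rests on a few compounds, and the source may have more. Where it says the series, first, only, none or still open, it means among the compounds named here.

Measured in a functional assay on CUTLL1 cells (Homo sapiens) for inhibition, read by resazurin assay, with a stated time of 48 h, in the absence of a further agent; on this read-out higher numbers stand for an effect only at larger amounts of compound and lower numbers for an effect already at smaller amounts:

Compound 1 `Nc1ncc(-c2ccccn2)c(C2CC2)n1`: > 100000 nM (a limit)
Compound 2 `Nc1ncc(-c2ccccc2)c(C2CC2)n1`: > 100000 nM (a limit)
Compound 3 `Nc1ncc(-c2ccnc(F)c2)c(C2CC2)n1`: > 100000 nM (a limit)

Compound 3 gives > 100000 nM, which is a limit of the assay and not a number. The other two compounds offer no firmer reference, as the set shows only (the limit of > 100000 nM in this assay, at which 3 of the 3 values shown sit).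

Compound 4 `Nc1ncc(-c2ccnc(Cl)c2)c(C2CC2)n1` carries chloro in place of fluoro on an aromatic carbon, next to the ring nitrogen: chloro in place of fluoro on an aromatic carbon. Among the measured compounds shown here, no measured step between these compounds shows what such an exchange does in this assay. The most likely outcome is therefore no clear change, with compound 4 staying at the limit. If a number does appear, only a modest step toward lower numbers is expected. The expected step of an at least 1.4-fold lower number from compound 3 to compound 4 (0.15 log units; that floor lies within the scatter) is an estimate measured against a limit, so it is a loose one. Compound 4 is estimated at 70000 nM, with an expected range from 15000 nM to 100000 nM.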

Compound 4, half-maximal effective concentration: > 100000 nM
Compound 4 gave a limit, no number; the forecaster's own chance of this, stated with the estimate: 65%; at least 1.4-fold (0.15 log units) between middle value and limit.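

Compound 3 and compound 4 both stand at a limit in this assay, so no step can be read for chloro in place of fluoro on an aromatic carbon: the limit of > 100000 nM in this assay, at which 4 of the 4 values shown sit.

The compounds shown leave open which change to the shared core, if any, would yield an actual number in this assay.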